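Swapping the Aryl Group on a Shared Core

The source may hold more compounds than are shown below. What is called first, only, known or untested is meant among the compounds shown, and "the series" means these compounds.

Compound 1, `O=[N+]([O-])c1ccc(CN2CCC(n3cc(CC(OCc4cc(-c5ccc(F)cc5)no4)c4ccc(Br)cc4)nn3)CC2)cc1`: 4000 nM
Compound 2, `COc1cccc(-c2cc(COC(Cc3cn(C4CCN(Cc5ccc([N+](=O)[O-])cc5)CC4)nn3)c3ccc(Br)cc3)on2)c1`: > 25000 nM

Of the compounds shown here, two built on one shared core have been tested in a functional assay on MDA-MB-468 cells (Homo sapiens) for cytotoxicity, with a stated time of 48 h; on this read-out higher numbers stand for weaker inhibition and lower numbers for stronger inhibition. Compound 1 gives 4000 nM in this assay. Compound 2 gives > 25000 nM, which is a limit of the assay rather than a number (the limit of > 25000 nM in this assay, at which 1 of the 2 values shown sits). Compound 2 thus stands at the weaker end of what has been seen, and only a range is known for it. Among the compounds with values here, the single measured step, an at least 6.2-fold higher number from compound 1 to compound 2 (0.79 log units; beyond the scatter), shows that exchanging the aryl group on this part of the core can shift the read-out markedly. Compound 3 `O=[N+]([O-])c1ccc(CN2CCC(n3cc(CC(OCc4cc(-c5ccccc5Br)no4)c4ccc(Br)cc4)nn3)CC2)cc1` differs from compound 2 at the same position: 2-bromophenyl in place of 3-methoxyphenyl on an aromatic carbon. The measured step bears on this change only loosely, since the entering group matches neither measured aryl group, although compound 3, like compound 1 with its 4000 nM, carries a halogen on that ring. Compound 3 is therefore expected to give about 10000 nM, with a range of 3000 nM to 40000 nM. This estimate means an expected step of an at least 2.5-fold lower number from compound 2 to compound 3 (0.39 log units; beyond the scatter).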

Compound 3, half-maximal inhibitory concentration: > 25000 nM
Compound 3: no number, only a limit; the forecaster's own chance of this, stated with the estimate: 35%; at least 2.5-fold (0.39 log units) between middle value and limit.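

In this assay, a halogen on this aryl ring is not enough to hold the read-out of compound 1: the change from 4-fluorophenyl to 2-bromophenyl brings an at least 6.2-fold higher number from compound 1 to compound 3 (0.79 log units; beyond the scatter). Two different replacements of 4-fluorophenyl, 3-methoxyphenyl without a halogen and 2-bromophenyl with one, have now both given weaker inhibition than compound 1, so among the three compounds shown, only the 4-fluorophenyl compound gives a measurable number. Compound 2 and compound 3 sit at the same limit of the assay, which is not a number, and the step between them cannot be read: the limit of > 25000 nM in this assay, at which 2 of the 3 values shown sit.

Compound 3 differs from compound 1 both in which halogen the ring carries and in where it sits on that ring, and the compounds shown do not separate these two changes. They also leave open how a plain phenyl, a 4-chlorophenyl or a 4-aminophenyl would read at this position on the shared core, and whether any group here could give stronger inhibition than 4-fluorophenyl.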